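This account rests on a few compounds, and the source may have more. Where it says the series, first, only, none or still open, it means among the compounds named here.

The measurements come from a functional assay on MDA-MB-435 cells (Homo sapiens) for inhibition, read by sulforhodamine B assay, with a stated time of 48 h; a lower number here means a stronger inhibitor of growth, a higher number a weaker inhibitor of growth.

Compound 1 `CCOC(=O)[C@H](CCC(=O)O)NC(=O)c1ccc(CNc2nc3cc(N)cc(N)c3nc2-c2ccccc2)cc1`: < 100000 nM, which is a limit of the assay.
Compound 2 `Nc1cc(N)c2nc(-c3ccccc3)c(NCc3ccc(Cl)c(Cl)c3)nc2c1`: 7590 nM
Compound 3 `COc1cc(CNc2nc3cc(N)cc(N)c3nc2-c2ccccc2)cc(OC)c1OC`: 912 nM

Of the two compounds with a number, compound 2 stands at the higher one, and compound 3 lies below it by more than the usual scatter. Compound 1 sits at the limit of < 100000 nM in this assay, at which 1 of the 3 values shown sits.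

Compound 4 `Nc1cc(N)c2nc(-c3ccccc3)c(NCc3ccc(F)cc3)nc2c1` is not yet measured and differs from compound 2 in one place: 4-fluorophenyl in place of 3,4-dichlorophenyl on a saturated chain carbon bound to a nitrogen on an aromatic ring. No measured pair among these compounds shows what such a change does, so the direction is uncertain. In this assay a modest rise is expected, a step estimated at a 1.6-fold higher number from compound 2 to compound 4 (0.20 log units; within the scatter). For compound 4 the estimate is 12000 nM, with a likely range from 3000 nM to 45000 nM.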

Compound 4, concentration for total growth inhibition: 3720 nM
Compound 4: middle estimate off by 3.2-fold (0.51 log units), on the high side, within the range that was stated.
By their numbers in this assay, from the lowest: compound 3; then compound 4; then compound 2.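

On a saturated chain carbon bound to a nitrogen on an aromatic ring, 4-fluorophenyl in place of 3,4-dichlorophenyl gives, in this assay, a 2.0-fold lower number from compound 2 to compound 4 (0.31 log units; beyond the scatter). Among the compounds shown here, this is the first pair here that differs in one place, and it shows that the number responds to what the phenyl ring at this position carries. For the compounds shown here, neither chlorine is needed for growth inhibition at this level, though the single step cannot separate losing the chlorines from gaining the fluorine.

Going by these compounds, whether an amine or a hydroxyl on this ring, or a longer chain leading to it, would shift the number remains open. Nothing measured here gives a reason for the step.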